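A few compounds are considered here, and "the series" means these few. Any claim that something is new, unique, unknown or untested is made for them only; others in the source may bear on it.

Compound 1: `Oc1ccc(Br)cc1-c1cc(-c2ccccc2Cl)[nH]n1` with 32% in an assay on isolated protein for inhibition of Polyunsaturated fatty acid lipoxygenase ALOX15 (Homo sapiens), read by spectrophotometry, tested at 20 uM; a higher number here means more inhibition at the concentration tested (going by the name of the read-out), a lower number less inhibition.
Compound 2: `Cc1ccccc1-c1cc(-c2ccccc2O)[nH]n1` with 92% in this assay.

Of these two numbers, compound 1 holds the lower one, and its value lies beyond the scatter below that of compound 2. Compound 3, `Oc1ccc(Cl)cc1-c1cc(-c2ccccc2Cl)[nH]n1`, is not yet measured. It differs from compound 1 by a single change: chloro in place of bromo on an aromatic carbon. Among the measured compounds shown here, no measured pair shows the effect of such an exchange, so nothing in the data fixes its size. Since bromo and chloro differ only in the one atom exchanged, the step of a number 2 percentage points lower from compound 1 to compound 3 (within the scatter) is expected to stay within the scatter. Compound 3 is therefore estimated at 30%, within a range from 10% to 50%.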

Compound 3, a percentage reported as inhibition, at one concentration (the size of the read-out at that concentration, not a potency): 29%
For compound 3 the middle estimate is 1 percentage points above the measured one, within the range that was stated.
By their numbers in this assay, from the lowest: compounds 3 and 1 (each within the scatter of the next); then compound 2.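

At the aromatic carbon para to a hydroxy group, this assay now gives a measured exchange of halogens: chloro in place of bromo gives a number 3 percentage points lower from compound 1 to compound 3 (within the scatter). The earlier compounds shown here held no such pair, and this one shows that bromo and chloro cannot be told apart at this place in this read-out. Nothing measured here explains this result. Going by these compounds, whether an amine, a methoxy group or a carboxylic acid on this carbon would change the inhibition stays open. So does whether fluoro would behave like these two halogens.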